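The source may report more compounds than this note shows. Statements on the series, on what has been measured and on what is new or still open speak of the compounds shown alone.

Measured compounds:

compound 1 `CCCN(CCC)c1cccc2nc(Nc3c(C)cc(C)cc3C)c(=O)[nH]c12`: 100 nM
compound 2 `CCCN(CCC)c1cccc2nc(Nc3c(OC)cc(OC)cc3OC)c(C)cc12`: > 1000 nM
compound 3 `CCCN(CCC)c1cccc2nc(Oc3c(OC)cc(COC)cc3OC)c(C)cc12`: 138 nM

All three were tested in an assay on HEK293 cells for displacement of a labelled ligand from corticotropin-releasing factor receptor 1 (Homo sapiens), read by scintillation proximity assay, with a stated time of 2 h; a lower number here means a stronger inhibitor, a higher number a weaker inhibitor. Compound 1 gives 100 nM in this assay. Compound 3 gives 138 nM in this assay, and the gap between compound 3 and compound 1 falls within the scatter of repeated measurements, so the two cannot be told apart. For compound 2 this assay reports only a limit, > 1000 nM, not a number (the limit of > 1000 nM in this assay, at which 1 of the 3 values shown sits). Compound 3 therefore sits alongside compound 1 among the two numbers that exist, with compound 2 known only as a limit.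

Compound 4 `COCc1cc(OC)c(Oc2nc3cccc(N(CC4CCOCC4)CC4CC4)c3cc2C)c(OC)c1` has not yet been tested in this assay. It differs from compound 3 in one place: (cyclopropylmethyl)((oxan-4-yl)methyl)amino in place of dipropylamino on an aromatic carbon. For the measured compounds named here, no measured pair in this set changes the group on that aromatic carbon, so there is no step to lean on. With the shared core, the aryl ether and the methyl group all kept as in compound 3, the expectation is that compound 4 stays close to compound 3, with a shift of a 1.3-fold lower number from compound 3 to compound 4 (0.10 log units; within the scatter) in this assay, not beyond the scatter. Compound 4 is therefore estimated at 110 nM in this assay, with a range from 30 nM to 400 nM.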

Compound 4, half-maximal inhibitory concentration: 762 nM
Compound 4: the middle estimate sits 6.9-fold (0.84 log units) below what was measured, outside the stated range (above it).
By their numbers in this assay, from the lowest: compounds 1 and 3 (each within the scatter of the next); then compound 4. At a limit, above all of these: compound 2.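

For the compounds shown here, until now no measured pair changed the group on this aromatic carbon, and the one step now available shows that this position is sensitive to what sits on it: in this assay, (cyclopropylmethyl)((oxan-4-yl)methyl)amino in place of dipropylamino gives a 5.5-fold higher number from compound 3 to compound 4 (0.74 log units; beyond the scatter). Dipropylamino has no ring, while the entering group has a three-membered ring of carbon only and a six-membered ring with a hetero atom, so in this pair the larger group with the added rings gives the weaker inhibitor, with the rest of the molecule unchanged. Going by these compounds alone, nothing measured here accounts for this change, and the single step does not separate the contribution of the cyclopropylmethyl part from that of the oxan-4-yl part.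

Still open, on these data alone, is whether either part alone, paired with a propyl chain on the same nitrogen, would keep compound 3's value, and how a smaller diethylamino group or a morpholine ring would compare on that aromatic carbon. Also open, as far as these compounds go, is whether the same exchange would give a step of similar size on the core of compound 1.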